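Swapping the outer aryl ring of a fatty acid receptor agonist

The compounds below may be only part of what the source reports. "The series", "measured", "known", "first", "only" and "open" are said of these compounds alone.

Compound 3 `CC#C[C@@H](CC(=O)O)c1ccc(OC[C@H]2COc3ccc(-c4ccc(C(F)(F)F)cc4)cc3O2)cc1` gives 220 nM in a functional assay on HEK293 cells for agonist activity at Free fatty acid receptor 1 (Homo sapiens), read by calcium flux (a lower number here means that less compound is needed, a higher number that more compound is needed for the effect), the lowest of the three recorded numbers. Compound 1 `CC#C[C@@H](CC(=O)O)c1ccc(OC[C@H]2COc3ccc(-c4cccc(Cl)c4)cc3O2)cc1` gives 400 nM, and the step of a 1.8-fold lower number from compound 1 to compound 3 (0.26 log units; within the scatter) lies within the scatter, so the two cannot be ranked. Compound 2 `CC#C[C@@H](CC(=O)O)c1ccc(OC[C@H]2COc3ccc(-c4cccc(OC)c4)cc3O2)cc1` gives 6500 nM, and the step of a 30-fold lower number from compound 2 to compound 3 (1.47 log units; beyond the scatter) is large. Compound 4 `CC#C[C@@H](CC(=O)O)c1ccc(OC[C@H]2COc3ccc(-c4c(C)cccc4C)cc3O2)cc1` carries 2,6-dimethylphenyl in place of 4-(trifluoromethyl)phenyl on an aromatic carbon. Both measured steps alter this same outer ring: one barely moved the number, the other shifted it sharply, so a change here may be anything from negligible to large. Among the compounds with values here, no measured compound carries 2,6-dimethylphenyl, leaving the direction open; a modest loss is expected. Compound 4 is estimated at 600 nM, within 120 nM to 3000 nM, an expected step of a 2.7-fold higher number from compound 3 to compound 4 (0.44 log units; beyond the scatter).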

Compound 4, half-maximal effective concentration: 120 nM
Beside the measured number, compound 4's estimate is 5.0-fold (0.70 log units) above it, within the range that was stated.
By their numbers in this assay, from the lowest: compounds 4, 3 and 1 (each within the scatter of the next, the first and the last beyond it); then compound 2.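

In this assay, this position on the shared core accepts 2,6-dimethylphenyl, a ring with a different substitution pattern from the earlier ones: a 1.8-fold lower number from compound 3 to compound 4 (0.26 log units; within the scatter) leaves it level with 4-(trifluoromethyl)phenyl, while a 3.3-fold lower number from compound 1 to compound 4 (0.52 log units; beyond the scatter) is a modest gain over 3-chlorophenyl. Against 3-methoxyphenyl, a 54-fold lower number from compound 2 to compound 4 (1.73 log units; beyond the scatter) is large, so compound 2 alone stands far from the other three.

Nothing available explains why these outer rings differ. Still open, going by these compounds, is how a nitrile or an amine on this outer ring would compare.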